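The source may hold more compounds than are shown below. What is called first, only, known or untested is meant among the compounds shown, and "the series" means these compounds.

Measured so far: compound 1 `Nc1cccc2c(-c3cccc(NC(=O)c4ccc5c(c4)OCCO5)c3)ccnc12`; compound 2 `Nc1cccc2c(-c3cccc(NC(=O)c4nccs4)c3)ccnc12`; compound 3 `COc1ccc(C(=O)Nc2cccc(-c3ccnc4c(NC(C)=O)cccc34)c2)cc1OC`.

In a functional assay on Malme-3M cells (Homo sapiens) for antiproliferative activity, read by sulforhodamine B assay, with a stated time of 48 h (on this read-out lower numbers stand for stronger inhibition and higher numbers for weaker inhibition), compound 1 gives only a limit, > 20000 nM. Compound 2 gives 12500 nM, and compound 3 gives 2000 nM. Compound 3 thus holds the lowest of the two numbers shown, and its gap to compound 2 lies beyond the scatter.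

Compound 4 `CC(=O)Nc1cccc2c(-c3cccc(NC(=O)c4ccc5c(c4)OCCO5)c3)ccnc12` differs from compound 3 by 2,3-dihydro-1,4-benzodioxin-6-yl in place of 3,4-dimethoxyphenyl on a carbonyl carbon. Among the measured compounds shown here, no measured step exchanges these two groups directly. For the measured compounds named here, the one step that touches the entering group is an at least 1.6-fold lower number from compound 1 to compound 2 (0.20 log units; that floor lies within the scatter), where taking it away from compound 1 moved from a limit of > 20000 nM in this assay, at which 1 of the 3 values shown sits, to a number in compound 2. That points toward weaker inhibition with the entering group, so compound 4 is expected to show a 2.5-fold higher number from compound 3 to compound 4 (0.40 log units; beyond the scatter), toward a higher number. Compound 4 is estimated at 5000 nM, between 1500 nM and 20000 nM.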

Compound 4, half-maximal inhibitory concentration: > 20000 nM
Compound 4 was reported as a limit (the forecaster's own chance of this, stated with the estimate: 20%); at least 4.0-fold (0.60 log units) between middle value and limit.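

In this assay the exchange at this carbonyl carbon gives an at least 10-fold higher number from compound 3 to compound 4 (1.00 log units; beyond the scatter) with the acetyl group kept on the shared core, so two groups of equal atom count do not behave alike here. The step between compound 1 and compound 4 cannot be read, since both values are limits. Compound 4 joins compound 1 at a limit: the limit of > 20000 nM in this assay, at which 2 of the 4 values shown sit.

On these data alone, it remains open whether a single methoxy group or an amine on this phenyl ring would hold the number of compound 3, and how 1,3-thiazol-2-yl behaves with acetyl present.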